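A few compounds are considered here, and "the series" means these few. Any claim that something is new, unique, unknown or untested is made for them only; others in the source may bear on it.

Compound 1 `CCCCCCCCc1ccc(OC(C)C(=O)Cn2nnc(-c3ccccc3)n2)cc1`: 40%
Compound 2 `CC(Oc1ccc(-c2ccccc2)cc1)C(=O)Cn1nnc(-c2ccccc2)n1`: < 5%, a limit of the assay

For the measured compounds named here, in an ADME assay on S9 fraction from liver (Rattus norvegicus) for metabolic stability, read by LC-MS, using NADPH, with a stated time of 30 min (a lower number here means that less of the compound is left, a higher number that more of the compound is left), compound 1 gives 40%, the only actual number so far. Going by the values given here, the one other reading is a limit, held by compound 2: the limit of < 5% in this assay, at which 1 of the 2 values shown sits.

Compound 3 `CCCCCCCCc1ccc(OC(C)C(=O)Cn2nnc(-c3ccc(C(=O)O)cc3)n2)cc1` differs from compound 1 by carboxy in place of hydrogen on an aromatic carbon. This is carboxy in place of hydrogen on an aromatic carbon, para to a large group, that is, phenyl to 4-carboxyphenyl.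

Among the compounds with values here, one measured step bears on this, and only indirectly: a number at least 35 percentage points lower from compound 1 to compound 2 (beyond the scatter). That large step, phenyl in place of octyl on an aromatic carbon, lies at another place in the structure. It shows that this assay can move strongly, but gives no direction for the new change. The expected change is a number 5 percentage points higher from compound 1 to compound 3 (within the scatter), a step within the scatter, with much uncertainty. The estimate for compound 3 is 45%, with an expected range of 15% to 75%.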

Compound 3, percent of the compound remaining: 55%
Compound 3: the middle estimate sits 10 percentage points below what was measured; low and high end bracket the measured number.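

In this assay, the phenyl of compound 1 now proves open to substitution: carboxy in place of hydrogen on an aromatic carbon, para to a large group, gives a number 15 percentage points higher from compound 1 to compound 3 (beyond the scatter). The only earlier step, a number at least 35 percentage points lower from compound 1 to compound 2 (beyond the scatter), lay at another place in the structure, so this is the first change shown to raise the number rather than lower it. The rise rests on a single pair with the octyl chain kept, and nothing measured gives a reason for it.

Whether the same rise would appear with the biphenyl-type side of compound 2 remains open, as that combination is not among the compounds shown. Also open, as far as these compounds go, is whether a carboxylic acid is specifically required at this place, or whether a primary amide, a nitrile or an amine would behave alike.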